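Spiro series: methoxy for fluoro on the pendant aryl

The compounds below may be only part of what the source reports. "The series", "measured", "known", "first", "only" and "open" are said of these compounds alone.

Three compounds of the shared core have numbers in a functional assay on HeLa cells (Homo sapiens) for cytotoxicity, read by MTT assay, with a stated time of 72 h; on this read-out lower numbers stand for stronger inhibition and higher numbers for weaker inhibition. Compound 1 `COc1ccc([C@@H]2[C@@H](c3ccccc3)N[C@]3(C(=O)Nc4ccc(Cl)cc43)[C@]23CNc2c(cccc2[N+](=O)[O-])C3=O)cc1` gives 16000 nM. Compound 2 `O=C1c2cccc([N+](=O)[O-])c2NC[C@@]12[C@H](c1ccc(Cl)cc1)[C@@H](c1ccccc1)N[C@]21C(=O)Nc2ccc(F)cc21` gives 25000 nM. Compound 3 `O=C1c2cccc([N+](=O)[O-])c2NC[C@@]12[C@H](c1ccc(F)cc1)[C@@H](c1ccccc1)N[C@]21C(=O)Nc2ccc(F)cc21` gives 20000 nM. Compound 3 stands second highest of the three, within the scatter of both compound 1 and compound 2, so no order among them can be claimed.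

One single-point step is known: a 1.3-fold lower number from compound 2 to compound 3 (0.10 log units; within the scatter). It concerns an exchange of halogens and does not bear on the change now considered.

Compound 4 `COc1ccc([C@@H]2[C@@H](c3ccccc3)N[C@]3(C(=O)Nc4ccc(F)cc43)[C@]23CNc2c(cccc2[N+](=O)[O-])C3=O)cc1` differs from compound 3 by methoxy in place of fluoro on an aromatic carbon. Among the measured compounds shown here, no measured step covers a fluoro to methoxy exchange. Compound 1 carries the methoxy group but differs from compound 4 elsewhere as well, so its value only sets a rough mark. All three numbers sit in a narrow band, and the expectation is that compound 4 stays in that band, with a step of a 1.2-fold lower number from compound 3 to compound 4 (0.07 log units; within the scatter) expected not to exceed the scatter. On these data alone, the estimate for compound 4 in this assay is 17000 nM, with a range from 8500 nM to 34000 nM, the range being wide since the change is untested here.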

Compound 4, half-maximal inhibitory concentration: 24000 nM
For compound 4 the middle estimate is 1.4-fold (0.15 log units) below the measured one; low and high end bracket the measured number.
By their numbers in this assay, from the lowest: compounds 1, 3, 4 and 2 (each within the scatter of the next).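

In this assay, the exchange of 4-fluorophenyl for 4-methoxyphenyl now has a direct reading on the shared core, a 1.2-fold higher number from compound 3 to compound 4 (0.08 log units; within the scatter), and methoxy in place of chloro at the same place reads a 1.0-fold lower number from compound 2 to compound 4 (0.02 log units; within the scatter). Among the compounds shown here, at this place, para to a large group, the extra heavy atom and the hydrogen-bond acceptor that methoxy brings therefore come with no step that stands out from repeated measurement, so fluoro, chloro and methoxy cannot be told apart here. Compound 4 also supplies a second reading of fluoro in place of chloro, a 1.5-fold higher number from compound 1 to compound 4 (0.18 log units; within the scatter), and the two readings of that change agree as far as this assay can tell: the same change on two cores in this assay, a 1.3-fold lower number (0.10 log units; within the scatter) from compound 2 to compound 3 and a 1.5-fold higher number (0.18 log units; within the scatter) from compound 1 to compound 4, 1.9-fold (0.27 log units) apart, within the scatter of two such steps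

On these data alone, how an amine, a carboxylic acid or a longer chain such as ethoxy would read at this place stays open. For the compounds shown here, every step so far lies within the scatter, so it also remains open whether any exchange at this place can give a step beyond it.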